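From methoxy to (oxan-2-yl)methoxy on a shared core

The compounds below may be only part of what the source reports. "The series", "measured", "known", "first", "only" and "open" are said of these compounds alone.

In a functional assay (aorta) with Oryctolagus cuniculus as the target (on this read-out higher numbers stand for weaker inhibition and lower numbers for stronger inhibition), compound 2 `CO/C(O)=C1\C(C)=NC(C)=C(C(=O)OCCCN2C(=O)c3ccccc3S2(=O)=O)C1c1ccccc1Cl` gives 1.8 nM and lies within the scatter of compound 1 `CO/C(O)=C1\C(C)=NC(C)=C(C(=O)OCCCN2C(=O)c3ccccc3S2(=O)=O)C1c1cccc([N+](=O)[O-])c1` at 2.6 nM on the same scale. For the measured compounds named here, the only measured step (a 1.4-fold lower number from compound 1 to compound 2 (0.16 log units; within the scatter)) swaps 3-nitrophenyl for 2-chlorophenyl, in another place, so it says little here. Compound 3 `CC1=NC(C)=C(C(=O)OCCCN2C(=O)c3ccccc3S2(=O)=O)C(c2ccccc2Cl)/C1=C(\O)OCC1CCCCO1` differs from compound 2 by oxan-2-yl in place of hydrogen on a saturated chain carbon bound to an oxygen on an unsaturated carbon as methoxy becomes (oxan-2-yl)methoxy. Going by the values given here, no measured step covers this change, so any forecast is loose. The estimated change is a 2.2-fold higher number from compound 2 to compound 3 (0.35 log units; beyond the scatter) and would mean modestly weaker inhibition. In this assay the expected value for compound 3 is 4 nM (estimated range 0.8 nM to 20 nM).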

Compound 3, half-maximal inhibitory concentration: 7 nM
The estimate for compound 3 lay 1.8-fold (0.24 log units) below the measured number; measured number inside the range.
By their numbers in this assay, from the lowest: compounds 2 and 1 (each within the scatter of the next); then compound 3.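

In this assay, adding oxan-2-yl on the saturated chain carbon bound to an oxygen on an unsaturated carbon gives a 3.9-fold higher number from compound 2 to compound 3 (0.59 log units; beyond the scatter), a modest loss that lies beyond the scatter. Even with this added six-membered ring, compound 3 still gives 7 nM, so inhibition at this position survives a much larger group than methoxy. No evidence here explains the step. From the compounds shown here alone, whether a plain butoxy chain or a terminal amine would stay closer to compound 2 remains open. So does whether the same step holds with 3-nitrophenyl in place of 2-chlorophenyl.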